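The source may report more compounds than this note shows. Statements on the series, on what has been measured and on what is new or still open speak of the compounds shown alone.

Working notes on the aryl end of the series. The three measured compounds share the core of compound 1 `CC(C)C[C@H](N)c1cc(C(F)(F)F)ccc1N1CCN(C(=O)CCc2ccccc2Cl)CC1` and differ only in the aromatic group on the saturated chain carbon two bonds along the chain from the carbonyl carbon. In an assay on HEK293 cells for displacement of a labelled ligand from Melanocortin receptor 4 (Homo sapiens) (a higher number here means a weaker inhibitor, a lower number a stronger inhibitor), compound 1 gives 1700 nM. Compound 2 `CC(C)C[C@H](N)c1cc(C(F)(F)F)ccc1N1CCN(C(=O)CCc2ccccc2O)CC1` gives 3300 nM in this assay, and compound 3 `CC(C)C[C@H](N)c1cc(C(F)(F)F)ccc1N1CCN(C(=O)CCc2c(Cl)cccc2Cl)CC1` gives 2600 nM. Compound 3 sits with the other two: its steps to compound 2 and to compound 1 are both within the scatter, as is a 1.9-fold higher number from compound 1 to compound 2 (0.29 log units; within the scatter) and a 1.3-fold lower number from compound 2 to compound 3 (0.10 log units; within the scatter).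

Compound 4 `COc1cc(OC)c(OC)cc1CCC(=O)N1CCN(c2ccc(C(F)(F)F)cc2[C@@H](N)CC(C)C)CC1` is not yet measured. The change from compound 3 is 2,4,5-trimethoxyphenyl in place of 2,6-dichlorophenyl on a saturated chain carbon, two bonds along the chain from a carbonyl carbon. For the measured compounds named here, the steps that bear on it, a 1.9-fold higher number from compound 1 to compound 2 (0.29 log units; within the scatter) and a 1.3-fold lower number from compound 2 to compound 3 (0.10 log units; within the scatter), were both within the scatter, so changes of the aromatic group at this place have so far not moved the number in this assay. For compound 4 the expected step is therefore a 1.2-fold higher number from compound 3 to compound 4 (0.06 log units; within the scatter), that is, none beyond the scatter. The estimate for compound 4 in this assay is 3000 nM, with a range from 1200 nM to 8000 nM.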

Compound 4, inhibition constant: 6100 nM
Estimate against measurement, compound 4: 2.0-fold (0.31 log units) below; the range from low to high includes it.
By their numbers in this assay, from the lowest: compounds 1, 3, 2 and 4 (each within the scatter of the next, the first and the last beyond it).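

For the compounds shown here, the aromatic group at this place does register in this assay: a 2.3-fold higher number from compound 3 to compound 4 (0.37 log units; beyond the scatter) and a 3.6-fold higher number from compound 1 to compound 4 (0.55 log units; beyond the scatter) are the first steps here to lie beyond the scatter, and both are modest. The 2-hydroxyphenyl compound is not separated from the new group, since a 1.8-fold higher number from compound 2 to compound 4 (0.27 log units; within the scatter) stays within the scatter, so the 2,4,5-trimethoxyphenyl group stands apart from only two of the three groups shown. No measurement shown bears on what lies behind these steps.

The compounds shown do not tell whether the three methoxy groups act together or whether one alone carries the step. Also open, as far as these compounds go, is how the number responds to an amine or a carboxylic acid on the aromatic group, or to a longer chain leading to it.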